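A few compounds are considered here, and "the series" means these few. Any claim that something is new, unique, unknown or untested is made for them only; others in the source may bear on it.

The measured compounds:
compound 1, `CC1(C)Cc2c(sc(NC(=O)c3nnc[nH]3)c2C(N)=O)C(C)(C)O1`, 467 nM
compound 2, `CC1(C)Cc2c(sc(NC(=O)c3ccn[nH]3)c2C(N)=O)C(C)(C)O1`, 3 nM
compound 3, `CC1(C)Cc2c(sc(NC(=O)C(C)(C)CO)c2C(N)=O)C(C)(C)O1`, 75 nM

In an assay on cells for positive allosteric modulation of Cystic fibrosis transmembrane conductance regulator variant F508del (Homo sapiens), with stated times of 10 min and 7 s, in the presence of a further agent that is not named here (a higher number here means that more compound is needed for the effect, a lower number that less compound is needed), compound 1 stands at the highest of the three numbers. Its nearest neighbour is compound 3, reached by a 6.2-fold lower number from compound 1 to compound 3 (0.79 log units; beyond the scatter), and its furthest is compound 2, reached by a 160-fold lower number from compound 1 to compound 2 (2.19 log units; beyond the scatter). Between those two, a 25-fold higher number from compound 2 to compound 3 (1.40 log units; beyond the scatter) shows how far apart the aromatic and the acyclic replacement lie.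

Compound 4, `CC(C)(C)CC(O)C(=O)Nc1sc2c(c1C(N)=O)CC(C)(C)OC2(C)C`, has not yet been measured in this assay. It differs from compound 1 at a single place: a group of 7 heavy atoms (6 carbon, 1 oxygen; no ring) in place of a group of 5 heavy atoms (2 carbon, 3 nitrogen; one five-membered aromatic ring with 3 hetero atoms), on a carbonyl carbon. Among the measured compounds shown here, the step that bears most directly on this change is the one from compound 1 to compound 3, where an acyclic group carrying a hydroxyl likewise replaced the 4H-1,2,4-triazol-3-yl group on the carbonyl carbon and brought a 6.2-fold lower number from compound 1 to compound 3 (0.79 log units; beyond the scatter). The step to compound 2 is of a different kind, since a five-membered aromatic ring remained there, and is taken as less informative. A modest lowering is therefore expected for compound 4, of about a 4.7-fold lower number from compound 1 to compound 4 (0.67 log units; beyond the scatter), with no basis in the measured compounds for a change as large as that seen with compound 2.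

Compound 4 is estimated to give 100 nM in this assay, within a range from 30 nM to 350 nM.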

Compound 4, half-maximal effective concentration: 0.54 nM
For compound 4 the middle estimate is 190-fold (2.27 log units) above the measured one; the measured number lies below the stated range.
By their numbers in this assay, from the lowest: compound 4; then compound 2; then compound 3; then compound 1.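

In this assay, the lowest number at this position belongs to an open-chain group and not to a five-membered aromatic ring, as a 5.6-fold lower number from compound 2 to compound 4 (0.74 log units; beyond the scatter) shows, and the reach of the change from the triazolyl group is far greater than compound 3 had suggested, with an 860-fold lower number from compound 1 to compound 4 (2.94 log units; beyond the scatter). Having no ring and carrying a hydroxyl therefore does not settle the number, since two such groups on the same carbonyl carbon stand far apart, with a 140-fold lower number from compound 3 to compound 4 (2.14 log units; beyond the scatter). The position thus responds strongly to the make-up of the acyclic chain itself, though nothing available here accounts for that response.

The compounds shown leave open whether the low number of compound 4 follows its hydroxyl, its larger carbon chain or the two together, as no pair among them differs in only one of these. As far as these compounds go, it also remains open how the number would move with an amine in place of that hydroxyl or with a longer chain, and whether any such group would go lower still on this core.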